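Removing the core bromo: an untested step from compound 1

The source may report more compounds than this note shows. Statements on the series, on what has been measured and on what is new or still open speak of the compounds shown alone.

Compounds measured so far:
compound 1, `COC(=O)C1=C(N)Oc2c(OC)cc(Br)cc2C1CC(=O)c1ccc(Cl)cc1`, 80.3%
compound 2, `COC(=O)C1=C(N)Oc2c(OC)cc(Br)cc2C1CC(=O)c1cccc(OC)c1`, 142%
compound 3, `COC(=O)C1=C(N)Oc2c(OC)cc(Br)cc2C1CC(=O)c1ccc(Br)cc1`, 50.2%

In a functional assay on MCF7 cells (Homo sapiens) for antiproliferative activity, read by sulforhodamine B assay, with a stated time of 72 h, tested at 10 uM (a lower number here means a stronger effect, a higher number a weaker effect of the compound at the concentration tested), compound 1 gives 80.3%, the second highest of the three numbers. Its nearest neighbour is compound 3, with a number 30.1 percentage points lower from compound 1 to compound 3 (beyond the scatter), and the furthest is compound 2, with a number 61.7 percentage points higher from compound 1 to compound 2 (beyond the scatter). Between the other two the difference is a number 91.8 percentage points lower from compound 2 to compound 3 (beyond the scatter).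

Compound 4, `COC(=O)C1=C(N)Oc2c(OC)cccc2C1CC(=O)c1ccc(Cl)cc1`, has not yet been measured in this assay. Compared with compound 1 it differs in one place: hydrogen in place of bromo on an aromatic carbon. Within the data shown here, none of the measured steps touches this position of the shared core; all three vary the aryl group on the carbonyl carbon. The step from compound 1 to compound 3 does exchange one halogen for another on an aromatic carbon, but on a different ring, so it offers only a loose guide, and its size, a number 30.1 percentage points lower from compound 1 to compound 3 (beyond the scatter), shows that a single-atom change can move this read-out well beyond the scatter. Among the measured compounds shown here, with no direct precedent, a modest shift is expected, more likely toward a higher number, and the expected step is a number 14.7 percentage points higher from compound 1 to compound 4 (beyond the scatter). Compound 4 is therefore estimated at 95%, within a range from 60% to 130%.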

Compound 4, a percentage reported as activity, at one concentration (the size of the read-out at that concentration, not a potency): 89.8%
For compound 4 the middle estimate is 5.2 percentage points above the measured one; the measured number falls inside the stated range.
By their numbers in this assay, from the lowest: compound 3; then compounds 1 and 4 (each within the scatter of the next); then compound 2.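

In this assay, the step at this position of the shared core, hydrogen in place of bromo on an aromatic carbon meta to a methoxy group, is a number 9.5 percentage points higher from compound 1 to compound 4 (within the scatter). All three earlier steps varied the aryl group on the carbonyl carbon and lay beyond the scatter, so this is the first step shown on the core itself and the first one that stays within it. With the 4-chlorophenyl group in place, this read-out at the tested concentration therefore does not separate the bromo compound from the hydrogen compound, although nothing shown gives a reason for this result.

The compounds shown leave open whether the same exchange would stay within the scatter with another aryl group on the carbonyl carbon, such as the 4-bromophenyl group of compound 3 or the 3-methoxyphenyl group of compound 2. They also leave open what an amine, a carboxylic acid or a longer chain at this position of the core would do to the read-out.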